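The compounds below may be only part of what the source reports. "The series", "measured", "known", "first", "only" and "open" are said of these compounds alone.

Measured compounds:
compound 1 `CCCCc1cn(C[C@H](O)[C@H]2OC(=O)C(OCc3ccccc3)=C2OCc2ccccc2)nn1`: 32800 nM in a functional assay on HepG2 cells (Homo sapiens) for antiproliferative activity, read by MTT assay, with a stated time of 72 h; a higher number here means a weaker inhibitor, a lower number a stronger inhibitor
compound 2 `CC(C)(C)OC(=O)N1CCN(C(=S)SCc2cn(C[C@H](O)[C@H]3OC(=O)C(OCc4ccccc4)=C3OCc3ccccc3)nn2)CC1`: > 100000 nM in this assay, a limit of the assay rather than a number

For the measured compounds named here, compound 1 holds the only numeric value here; the other entry is the limit of > 100000 nM in this assay, at which 1 of the 2 values shown sits. Compound 3 `Cc1ccc(S(=O)(=O)NCc2cn(C[C@H](O)[C@H]3OC(=O)C(OCc4ccccc4)=C3OCc3ccccc3)nn2)cc1` differs from compound 1 by ((4-methylphenyl)sulfonyl)amino in place of propyl on a saturated chain carbon bound to an aromatic carbon. Going by the values given here, no pair of measured compounds traces this change, so the size of the step is open; the step from compound 1 to compound 3 is expected to be modest and towards weaker inhibition, a 1.8-fold higher number from compound 1 to compound 3 (0.26 log units; within the scatter). Compound 3 is therefore estimated at 60000 nM in this assay, within 20000 nM to 150000 nM.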

Compound 3, half-maximal inhibitory concentration: 24900 nM
For compound 3 the middle estimate is 2.4-fold (0.38 log units) above the measured one; the range from low to high includes it.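

In this assay, the saturated chain carbon bound to an aromatic carbon accepts ((4-methylphenyl)sulfonyl)amino in place of propyl, bringing in a six-membered aromatic ring and a hydrogen-bond donor, with only a 1.3-fold lower number from compound 1 to compound 3 (0.12 log units; within the scatter). So at this place, a far larger group need not shift the read-out beyond the scatter. Compound 2, which carries a different large group, gives a limit and not a number: the limit of > 100000 nM in this assay, at which 1 of the 3 values shown sits.

From the compounds shown here alone, it remains open whether an amine or a carboxylic acid at this place would move the number beyond the scatter. The contributions of the sulfonyl part and the 4-methylphenyl ring also cannot be told apart.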